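Methoxycarbonyl for bromo: an unmeasured step in the series

This account rests on a few compounds, and the source may have more. Where it says the series, first, only, none or still open, it means among the compounds named here.

Two compounds have numbers in an assay on membranes from brain for displacement of a labelled ligand from Neuronal acetylcholine receptor; alpha4/beta2 (Rattus norvegicus); on this read-out higher numbers stand for weaker inhibition and lower numbers for stronger inhibition. Compound 1 `CSc1ncccc1OC[C@@H]1CCCN1C` gives 559 nM in this assay. Compound 2 `CN1CCC[C@H]1COc1cncc(Br)c1` gives 0.27 nM in this assay, the lowest of the two numbers, with compound 1 standing far higher and the gap well beyond the scatter. Compound 3 `COC(=O)c1cncc(OC[C@@H]2CCCN2C)c1` has not yet been measured in this assay. Its change from compound 2 is methoxycarbonyl in place of bromo on an aromatic carbon. Within the data shown here, no measured step of this kind exists, so the step is estimated as a moderate rise, beyond the scatter: a 30-fold higher number from compound 2 to compound 3 (1.47 log units; beyond the scatter). Compound 3 is thus expected to give about 8 nM in this assay, within 1 nM to 60 nM.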

Compound 3, inhibition constant: 1.45 nM
Compound 3: middle estimate off by 5.5-fold (0.74 log units), on the high side; low and high end bracket the measured number.
By their numbers in this assay, from the lowest: compound 2; then compound 3; then compound 1.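

In this assay, the place two atoms from the ring nitrogen takes methoxycarbonyl in place of bromo with only a modest rise: a 5.4-fold higher number from compound 2 to compound 3 (0.73 log units; beyond the scatter). Four heavy atoms and two hydrogen-bond acceptors enter where one bromine leaves, yet compound 3 still gives 1.45 nM, so a low number here does not depend on bromo. No available data explain the size of this step. Still open, on these data alone, is how a carboxylic acid, a primary amide or the longer ethoxycarbonyl would read at this same place.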